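A few compounds are considered here, and "the series" means these few. Any claim that something is new, unique, unknown or untested is made for them only; others in the source may bear on it.

Measured so far in a physicochemical assay for lipophilicity, read by HPLC, using the shake flask method; a lower number here means a more polar compound, a higher number a more lipophilic compound:
- compound 1 `CCCCCN(Cc1ccc(Cl)nc1)/C(C)=N/C#N`: 2.37
- compound 2 `CC(C)/C(=N\C#N)N(C)Cc1ccc(Cl)nc1`: 1.39

Of these two, compound 1 stands higher, and compound 2 lies below it by more than the scatter. Compound 3 `C=CCN(Cc1ccc(Cl)nc1)/C(C)=N/C#N` has not yet been measured. It departs from compound 1 at one place: vinyl in place of butyl on a saturated chain carbon bound to an amine nitrogen. That is vinyl in place of butyl on a saturated chain carbon bound to an amine nitrogen, or pentyl to allyl when cut one bond further out. A clear fall is expected in this assay, with an estimated step of a number 1.02 log units lower from compound 1 to compound 3 (beyond the scatter) beyond the scatter. For compound 3 the estimated value is 1.35, with an expected range from 1 to 1.7.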

Compound 3, partition coefficient: 1.56
Compound 3: middle estimate off by 0.21 log units, on the low side; measured number inside the range.
By their numbers in this assay, from the lowest: compounds 2 and 3 (each within the scatter of the next); then compound 1.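

Among these compounds, until now the compounds offered no step in this assay that turned on a single place; here, on a saturated chain carbon bound to an amine nitrogen, vinyl in place of butyl gives a number 0.81 log units lower from compound 1 to compound 3 (beyond the scatter). This shows that the number in this assay moves beyond the scatter with this one change on the shared core. No measurement shown accounts for the size of this step.

The step joins a shorter group with a double bond, so the two remain unseparated. Ethyl at this place would tell them apart, and a chain bearing an amine remains untested here.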